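Chloro for methyl on two cores, oral inhibition

This account rests on a few compounds, and the source may have more. Where it says the series, first, only, none or still open, it means among the compounds named here.

Compound 2 `Cc1ccc2[nH]cc(-c3nn[nH]n3)c(=O)c2c1` and compound 1 `O=c1c(-c2nn[nH]n2)c[nH]c2ccc(Cl)cc12` share one core; compound 3 `Cc1cccc2cc(C(=O)O)cnc12` and compound 4 `O=C(O)c1cnc2c(Cl)cccc2c1` share another, and the difference between the two cores is not broken down here. In a functional assay on the whole organism (strain Sprague-Dawley) for inhibition, with Rattus norvegicus as the target (a lower number here means that less compound is needed, a higher number that more compound is needed for the effect), compound 2 gives > 25 mg/kg, a limit of the assay. In this assay compound 1 gives > 25 mg/kg, also a limit. The change chloro in place of methyl on an aromatic carbon thus leaves a step that the two limits leave unreadable from compound 2 to compound 1. In this assay compound 3 gives > 25 mg/kg, again a limit. All measured values sit at the limit of > 25 mg/kg in this assay, at which 3 of the 3 values shown sit. Compound 4 carries the same kind of change, (chloro in place of methyl on an aromatic carbon), the place being meta and para to a fused ring in compound 1 but ortho and meta to a fused ring in compound 4. Compound 4 is expected to stay close to its parent, an estimated step that the limit leaves unreadable from compound 3 to compound 4. The value expected for compound 4 is 40 mg/kg, between 20 mg/kg and 100 mg/kg, most likely again reported only as a limit.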

Compound 4, minimum effective dose: 150 mg/kg
Compound 4: the middle estimate sits 3.8-fold (0.57 log units) below what was measured; measured number above the stated range.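

No step can be read from compound 3 to compound 4 in this assay. Compound 3 gives > 25 mg/kg, a limit. The compounds shown leave open how far chloro in place of methyl on an aromatic carbon shifts the dose on either core.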